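A few compounds are considered here, and "the series" means these few. Any claim that something is new, unique, unknown or untested is made for them only; others in the source may bear on it.

Measured compounds:
Compound 1, `CC(C)COc1ccc(-c2c(C#N)c(N)nc(SCC(N)=O)c2C#N)cc1`, gives 9%.
Compound 2, `N#Cc1c(N)nc(SCC(=O)NCO)c(C#N)c1-c1ccc(OCC2CC2)cc1`, gives 8%.
Compound 3, `N#Cc1c(N)nc2sc(C(N)=O)c(N)c2c1-c1ccc(OCC2CC2)cc1`, gives 13%.

All three numbers come from an assay on CHO cells for displacement of a labelled ligand from adenosine receptor A3 (Homo sapiens), read by scintillation counting, with a stated time of 120 min, tested at 1 uM; a lower number here means less inhibition, a higher number more inhibition at the concentration tested (going by the name of the read-out). Compound 1, compound 2 and compound 3 share one core and differ only in the group carried on the sulfur or in the ring that sulfur closes; their readings sit close together, and every gap between them lies within the scatter of this assay, so none of the three can be set apart from the others. Compound 2 therefore stands among its neighbours rather than beside them.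

The unmeasured compound is compound 4, `COC(=O)CSc1nc(N)c(C#N)c(-c2ccc(OCC3CC3)cc2)c1C#N`. Set against compound 2 it differs in one place: methoxy in place of (hydroxymethyl)amino on a carbonyl carbon. The rest of the molecule is unchanged. Going by the values given here, no pair of measured compounds that differ in one place is available, so the size of such a step has not been seen here. Given that compound 1, compound 2 and compound 3 all read low and alike, the expected step of a number 1 percentage points higher from compound 2 to compound 4 (within the scatter) is none beyond the scatter. Compound 4 is thus expected to give 9%, with a range from 0% to 22%.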

Compound 4, a percentage reported as inhibition, at one concentration (the size of the read-out at that concentration, not a potency): 1%
Beside the measured number, compound 4's estimate is 8 percentage points above it; low and high end bracket the measured number.
By their numbers in this assay, from the lowest: compounds 4, 2, 1 and 3 (each within the scatter of the next, the first and the last beyond it).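

Going by these compounds alone, exchanging (hydroxymethyl)amino for methoxy on a carbonyl carbon gives the first change in a single place seen in this set, and in this assay it comes out as a number 7 percentage points lower from compound 2 to compound 4 (within the scatter), so the two compounds cannot be told apart. At this position, then, an amide-type (hydroxymethyl)carbamoyl group and a methoxycarbonyl group give the same low picture, even though the group that leaves carries hydrogen-bond donors and the group that enters carries none, and neither group lifts the reading clear of the scatter at the concentration tested. No measurement is at hand that could explain this result.

As far as these compounds go, what stays open is whether any group on this carbonyl carbon can move the reading at all, for example a free carboxylic acid, a dimethylamino group or a longer chain such as butoxy in place of methoxy. With both readings this low, a single step also cannot show whether the position is truly indifferent to change or whether the shared core simply gives too little inhibition at this concentration for a difference to appear.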